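Swapping one side group across two matched pairs

The source may hold more compounds than are shown below. What is called first, only, known or untested is meant among the compounds shown, and "the series" means these compounds.

Compound 1 `CN(C)c1cccc(Oc2ccc3c(NCCCNCc4ccco4)ccnc3c2)c1` and compound 2 `c1ccc(Cc2ccc3c(NCCCNCc4ccco4)ccnc3c2)cc1` share a core and differ in a single group: benzyl in place of 3-(dimethylamino)phenoxy on an aromatic carbon. In an ADME assay on HepG2 cells (Homo sapiens) for cytotoxicity, read by luminescence, CellTiter-Glo and ATP content, with a stated time of 72 h (on this read-out lower numbers stand for an effect already at smaller amounts and higher numbers for an effect only at larger amounts of compound), compound 1 gives 16000 nM, and in this assay compound 2 gives 16000 nM, so that no change at the digits printed from compound 1 to compound 2 (within the scatter). Compound 3 `COc1ccc(F)cc1CNCCCNc1ccnc2cc(Oc3cccc(N(C)C)c3)ccc12` differs from compound 1 at a different place: 5-fluoro-2-methoxyphenyl in place of furan-2-yl on a saturated chain carbon bound to an amine nitrogen. In this assay compound 3 gives 3300 nM, which is a 4.8-fold lower number from compound 1 to compound 3 (0.69 log units; beyond the scatter); it stands lowest of the three measured numbers.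

Compound 4 `COc1ccc(F)cc1CNCCCNc1ccnc2cc(Cc3ccccc3)ccc12` has not yet been measured. It differs from compound 3 by benzyl in place of 3-(dimethylamino)phenoxy on an aromatic carbon, the same change, at the same place, that turns compound 1 into compound 2. The cores of the two pairs differ only as described between compound 1 and compound 3.

The step from compound 3 to compound 4 in this assay is expected to be no change at the digits printed from compound 3 to compound 4 (within the scatter) because no change at the digits printed from compound 1 to compound 2 (within the scatter). Compound 4 is therefore estimated at 3300 nM in this assay, expected to fall between 1500 nM and 7000 nM.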

Compound 4, half-maximal effective concentration: 7990 nM
The estimate for compound 4 lay 2.4-fold (0.38 log units) below the measured number, and the stated range ends below it.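

In this assay, putting benzyl in place of 3-(dimethylamino)phenoxy gives a 2.4-fold higher number from compound 3 to compound 4 (0.38 log units; beyond the scatter), and although this step lies beyond the scatter while no change at the digits printed from compound 1 to compound 2 (within the scatter) does not, the two steps cannot be told apart: the same change on two cores in this assay, no change at the digits printed (within the scatter) from compound 1 to compound 2 and a 2.4-fold higher number (0.38 log units; beyond the scatter) from compound 3 to compound 4, 2.4-fold (0.38 log units) apart, within the scatter of two such steps

The other change, 5-fluoro-2-methoxyphenyl in place of furan-2-yl, gives a 2.0-fold lower number from compound 2 to compound 4 (0.30 log units; within the scatter), and it too agrees with its earlier counterpart, a 4.8-fold lower number from compound 1 to compound 3 (0.69 log units; beyond the scatter): the same change on two cores in this assay, a 4.8-fold lower number (0.69 log units; beyond the scatter) from compound 1 to compound 3 and a 2.0-fold lower number (0.30 log units; within the scatter) from compound 2 to compound 4, 2.4-fold (0.38 log units) apart, within the scatter of two such steps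

So within these four compounds each change carries from one core to the other within the scatter, but two pairs per change are too few to show that this would hold on further cores or to fix the exact size of either step.

The compounds shown leave open whether the same carry-over would appear with other groups on that aromatic carbon, such as a plain phenoxy or a morpholine. They also leave open what a longer chain between the two amine nitrogens would do to these steps.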